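A Direct Aryl Amine in Place of a Benzyl Amine

The source may hold more compounds than are shown below. What is called first, only, known or untested is meant among the compounds shown, and "the series" means these compounds.

Of the compounds shown here, three sharing one core have been measured in a functional assay on Jurkat cells (Homo sapiens) for inhibition, read by CCK-8 assay, with a stated time of 48 h; a lower number here means a stronger inhibitor of growth, a higher number a weaker inhibitor of growth. Compound 1 `Cc1ccccc1Nc1nc(NCc2ccco2)ncc1Cl` gives only a limit of the assay, > 100000 nM, in this assay. Within the data shown here, compound 2 `Cc1ccccc1Nc1nc(Nc2ccccn2)ncc1Cl` gives 20100 nM in this assay, and the change an at least 4.9-fold lower number from compound 1 to compound 2 (0.69 log units; beyond the scatter) is the one measured step in the set. Compound 3 `COc1ccc(CNc2nc(Nc3ccc(N4CCN(C)CC4)cn3)ncc2Cl)cc1` gives 12900 nM in this assay; this is the lowest of the two numbers, though its gap to compound 2 lies within the scatter.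

Compound 4 `COc1cccc(Nc2nc(Nc3ccc(N4CCN(C)CC4)cn3)ncc2Cl)c1` is not yet measured. It differs from compound 3 by 3-methoxyphenyl in place of 4-methoxybenzyl on a nitrogen on an aromatic ring. Among the measured compounds shown here, the measured step that bears on it is the one from compound 1 to compound 2, where a group bound to the nitrogen through a single saturated carbon was exchanged for an aromatic ring bound directly, giving an at least 4.9-fold lower number from compound 1 to compound 2 (0.69 log units; beyond the scatter). For the measured compounds named here, the change from compound 3 to compound 4 is of the same kind, 3-methoxyphenyl in place of 4-methoxybenzyl on a nitrogen on an aromatic ring, so a lower number is expected in this assay, of modest size, since only one step supports it and the limit of > 100000 nM in this assay, at which 1 of the 3 values shown sits, leaves its true size open. Compound 4 is therefore expected to show 4000 nM in this assay, between 1000 nM and 15000 nM, a step of a 3.2-fold lower number from compound 3 to compound 4 (0.51 log units; beyond the scatter).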

Compound 4, concentration for 50% growth inhibition: 15800 nM
For compound 4 the middle estimate is 4.0-fold (0.60 log units) below the measured one, and the stated range ends below it.
By their numbers in this assay, from the lowest: compounds 3, 4 and 2 (each within the scatter of the next). At a limit, above all of these: compound 1.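

At this nitrogen, replacing 4-methoxybenzyl with 3-methoxyphenyl swaps a link through a saturated carbon for a direct bond to the aromatic ring, yet this assay shows a 1.2-fold higher number from compound 3 to compound 4 (0.09 log units; within the scatter), so the two compounds cannot be told apart here. The earlier step, an at least 4.9-fold lower number from compound 1 to compound 2 (0.69 log units; beyond the scatter), therefore does not hold as a general rule for this position: a directly bound aromatic ring gave a lower number in that pair, and compound 4 goes against this. That earlier step also differs in its groups, and its reading rests on compound 1, whose value is only a limit of the assay: the limit of > 100000 nM in this assay, at which 1 of the 4 values shown sits.

The change from compound 3 to compound 4 alters both the link to the nitrogen and the number on the methoxy group, and the compounds shown do not separate these two differences, which 4-methoxyphenyl on the same nitrogen would do. On these data alone, it also remains open whether any group on that aromatic ring matters in this assay, for example a carboxylic acid or a primary amine in place of the methoxy group of compound 4.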